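Shortening the carbamate chain on a selenocyanate series

This account rests on a few compounds, and the source may have more. Where it says the series, first, only, none or still open, it means among the compounds named here.

Measured so far:
- compound 1, `CCCCOC(=O)Nc1ccc([Se]C#N)cc1`: 31300 nM
- compound 2, `CCCCCCOC(=O)Nc1ccc([Se]C#N)cc1`: 40300 nM

In a functional assay on HT-29 cells (Homo sapiens) for cytotoxicity, read by MTT assay, with a stated time of 72 h (a lower number here means a stronger inhibitor of growth, a higher number a weaker inhibitor of growth), compound 1 gives 31300 nM and compound 2 gives 40300 nM. The two differ by an ethyl in place of hydrogen on a saturated chain carbon, four bonds along the chain from an oxygen next to a carbonyl group, and that change gave a 1.3-fold higher number from compound 1 to compound 2 (0.11 log units; within the scatter). Compound 2 thus has the highest of the two numbers, yet its gap to compound 1 is within the scatter, so no order between them can be read.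

Compound 3, `CCOC(=O)Nc1ccc([Se]C#N)cc1`, has not yet been measured. It differs from compound 2 by hydrogen in place of butyl on a saturated chain carbon, two bonds along the chain from an oxygen next to a carbonyl group, a shortening of the same chain that was lengthened between compound 1 and compound 2. For the measured compounds named here, the only step that bears on this change, a 1.3-fold higher number from compound 1 to compound 2 (0.11 log units; within the scatter), stayed within the scatter, so no step beyond the scatter is expected in this assay either. Compound 3 is therefore estimated at 30000 nM, with a range of 12000 nM to 75000 nM, an expected step of a 1.3-fold lower number from compound 2 to compound 3 (0.13 log units; within the scatter).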

Compound 3, concentration for total growth inhibition: 38000 nM
For compound 3 the middle estimate is 1.3-fold (0.10 log units) below the measured one; the range from low to high includes it.
By their numbers in this assay, from the lowest: compounds 1, 3 and 2 (each within the scatter of the next).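

Hydrogen in place of butyl gives a 1.1-fold lower number from compound 2 to compound 3 (0.03 log units; within the scatter), and hydrogen in place of ethyl gives a 1.2-fold higher number from compound 1 to compound 3 (0.08 log units; within the scatter) in this assay. Cut one bond further out, the first of these steps reads hexyl to ethyl, so this is a large cut in the chain on the oxygen, yet it stays within the scatter just as the earlier lengthening did, and the three compounds cannot be told apart by their numbers. Nothing on hand gives a reason for this flat result, which is seen here only in these three compounds and this one cell assay.

Still open, going by these compounds, is whether the chain matters at all outside this range: a methyl group, or a chain longer than hexyl such as decyl, could still give a step beyond the scatter. A benzyl group on the oxygen, or an amine or a carboxylic acid at the end of the chain, would test whether anything other than a plain saturated chain at this place moves the number.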